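Replacing an aryl urea with a hydroxycyclohexyl urea

The source may hold more compounds than are shown below. What is called first, only, known or untested is meant among the compounds shown, and "the series" means these compounds.

Measured compounds and their values:
compound 1 `N#Cc1ccccc1NC(=O)N1CCC(c2nc(-c3ccc4ccccc4n3)no2)CC1` — 190 nM
compound 2 `O=C(NC1CCCCC1)N1CCN(c2nc(-c3ccc4ccccc4n3)no2)CC1` — 53 nM
compound 3 `Cn1c(-c2noc(C3CCN(C(=O)NC4CCS(=O)(=O)CC4)CC3)n2)nc2ccccc21` — 350 nM

Three compounds have been run in a functional assay on Shh Light II cells (Mus musculus) for inhibition, read by a luciferase reporter; a lower number here means a stronger inhibitor, a higher number a weaker inhibitor. Compound 1 gives 190 nM, the second highest of the three numbers. Its nearest neighbour is compound 3, which gives 350 nM, a gap within the usual scatter, so no order between these two can be claimed. Compound 2 gives 53 nM, the lowest number, and its gap from compound 1 lies beyond the scatter.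

Compound 4 `O=C(NC1CCC(O)CC1)N1CCC(c2nc(-c3ccc4ccccc4n3)no2)CC1` has not yet been measured. It differs from compound 1 in one place: 4-hydroxycyclohexyl in place of 2-cyanophenyl on an amide-type nitrogen. The aromatic group on the amide-type nitrogen gives way to a saturated one bearing a hydroxyl.

For the measured compounds named here, no step between two measured compounds isolates this change, so the expectation rests on loose parallels. Compound 2, which carries a saturated group on its urea nitrogen rather than an aromatic one, gives 53 nM, though its core differs from that of compound 1. A modest shift toward a lower number seems plausible, though it may well fall within the scatter. The estimated step is a 1.9-fold lower number from compound 1 to compound 4 (0.28 log units; within the scatter). Compound 4 is expected to give about 100 nM, within a range of 35 nM to 300 nM.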

Compound 4, half-maximal inhibitory concentration: 2700 nM
The estimate for compound 4 lay 27-fold (1.43 log units) below the measured number, outside the stated range (above it).
By their numbers in this assay, from the lowest: compound 2; then compounds 1 and 3 (each within the scatter of the next); then compound 4.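

In this assay, putting 4-hydroxycyclohexyl in place of 2-cyanophenyl on the amide-type nitrogen gives a 14-fold higher number from compound 1 to compound 4 (1.15 log units; beyond the scatter), a large step beyond the scatter, with the rest of the structure unchanged. For the compounds shown here, this pair is the first to isolate a change at this position, and it shows that the position is far from indifferent to the group it carries; the saturated group of compound 2 sits on a different core, so compound 2 could not speak for this change on the core of compound 1. The data offer nothing that accounts for the size of this step.

The change removes the aromatic ring and the nitrile and adds the hydroxyl all at once, so this single step cannot say which of these parts matters most. A plain phenyl or an unsubstituted cyclohexyl on the core of compound 1 would begin to separate them, and a methoxy or an amine in place of the hydroxyl would show whether the loss follows that one substituent or the saturated ring itself.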